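The compounds below may be only part of what the source reports. "The series", "measured", "known", "first", "only" and "open" are said of these compounds alone.

Of the compounds shown here, three sharing one core have been measured in a functional assay on A549 cells (Homo sapiens) for antiproliferative activity, read by MTT assay, with a stated time of 48 h; on this read-out lower numbers stand for stronger inhibition and higher numbers for weaker inhibition. Compound 1 `N#CC1=C(N)Oc2c(c3nc4ccccc4nc3c3ccccc23)C12C(=O)N(Cc1cnnn1-c1ccccc1Br)c1ccccc12` carries a 2-bromophenyl group on an aromatic nitrogen. In this assay compound 1 gives only a limit, > 50000 nM. Compound 2 `N#CC1=C(N)Oc2c(c3nc4ccccc4nc3c3ccccc23)C12C(=O)N(Cc1cnnn1-c1ccc(N)cc1)c1ccccc12` bears a 4-aminophenyl in place of 2-bromophenyl on an aromatic nitrogen. In this assay compound 2 likewise gives only a limit, > 50000 nM. Compound 3 `N#CC1=C(N)Oc2c(c3nc4ccccc4nc3c3ccccc23)C12C(=O)N(Cc1cnnn1-c1ccc(S(N)(=O)=O)cc1)c1ccccc12` has a 4-sulfamoylphenyl in place of 2-bromophenyl on an aromatic nitrogen. In this assay compound 3 also gives only a limit, > 50000 nM. Compound 3 thus stands where the other two stand, at the limit of > 50000 nM in this assay, at which 3 of the 3 values shown sit. The steps a step that the two limits leave unreadable from compound 1 to compound 2, a step that the two limits leave unreadable from compound 1 to compound 3 and a step that the two limits leave unreadable from compound 2 to compound 3 have no readable size; both ends of each sit at the limit. Compound 4 `N#CC1=C(N)Oc2c(c3nc4ccccc4nc3c3ccccc23)C12C(=O)N(Cc1cnnn1-c1cc(Cl)ccc1Cl)c1ccccc12` is the unmeasured one, and the change is 2,5-dichlorophenyl in place of 4-sulfamoylphenyl on an aromatic nitrogen. Within the data shown here, none of the measured steps shows that a new group on this aromatic nitrogen brings the activity into the measurable range, so the expected step in this assay is a number no higher from compound 3 to compound 4 (the limit leaves the size open), most likely ending again at a limit. Compound 4 is therefore estimated at 50000 nM, between 20000 nM and 100000 nM.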

Compound 4, half-maximal inhibitory concentration: > 50000 nM
Compound 4: no number, only a limit; the forecaster's own chance of this, stated with the estimate: 80%; the middle value lies on the limit itself.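

In this assay compound 4 also gives only a limit, > 50000 nM. Its steps from compound 1, compound 2 and compound 3 therefore cannot be read: the limit of > 50000 nM in this assay, at which 4 of the 4 values shown sit. The compounds shown leave open how these groups on the aromatic nitrogen compare, and whether any of them brings activity into the measurable range.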